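Exchanging the aryl group on the shared core

The compounds below may be only part of what the source reports. "The series", "measured", "known", "first", "only" and "open" are said of these compounds alone.

Compound 1 `S=C(NCc1cccnc1)SCCc1nnn[nH]1` reaches only the assay limit > 100000 nM in a functional assay on SK-BR-3 cells (Homo sapiens) for cytotoxicity, read by resazurin assay, with a stated time of 72 h (a higher number here means a weaker inhibitor, a lower number a stronger inhibitor), which is a limit and not a number (the limit of > 100000 nM in this assay, at which 1 of the 3 values shown sits). Compound 2 `FC(F)(F)c1ccc(-c2nnc(CCSC(=S)NCc3cccnc3)o2)cc1` gives 2400 nM in this assay, and compound 3 `O=[N+]([O-])c1ccc(-c2nnc(CCSC(=S)NCc3cccnc3)o2)cc1` gives 1540 nM. Of the two numbers, compound 3 holds the smaller, yet the step of a 1.6-fold lower number from compound 2 to compound 3 (0.19 log units; within the scatter) stays within the scatter. Compound 4 `S=C(NCc1cccnc1)SCCc1nnc(-c2cc3ccccc3s2)o1` differs from compound 3 by 1-benzothiophen-2-yl in place of 4-nitrophenyl on an aromatic carbon. Within the data shown here, no measured step covers such an exchange of the whole aryl group; the only comparable step alters a substituent on that phenyl and is within the scatter. Compound 4 is therefore expected to give 1500 nM in this assay, within 400 nM to 6000 nM, so the estimated step of a 1.0-fold lower number from compound 3 to compound 4 (0.01 log units; within the scatter) is none beyond the scatter.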

Compound 4, half-maximal inhibitory concentration: 5320 nM
Beside the measured number, compound 4's estimate is 3.5-fold (0.55 log units) below it, within the range that was stated.
By their numbers in this assay, from the lowest: compounds 3 and 2 (each within the scatter of the next); then compound 4. At a limit, above all of these: compound 1.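

In this assay, among these compounds, the exchange of the whole aryl group gives a 3.5-fold higher number from compound 3 to compound 4 (0.54 log units; beyond the scatter) and is the only step at this position beyond the scatter, whereas a 1.6-fold lower number from compound 2 to compound 3 (0.19 log units; within the scatter) stayed within it. The position therefore does respond to the aryl group, if modestly, and 1-benzothiophen-2-yl does not simply stand in for 4-nitrophenyl. Nothing shown here accounts for this step. Still open, on these data alone, is how an amine or a carboxylic acid on the phenyl, or an unsubstituted phenyl, would compare with these aryl groups.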